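This account rests on a few compounds, and the source may have more. Where it says the series, first, only, none or still open, it means among the compounds named here.

Compound 2 `Cc1cnc(N[C@H]2CC[C@@H](CNC(=O)c3ccc(F)c(F)c3)CC2)nc1N(C)C` gives 120 nM in a functional assay on HEK293 cells for antagonist activity at melanin-concentrating hormone receptor 1 (Homo sapiens), read by FLIPR and calcium flux (on this read-out higher numbers stand for weaker inhibition and lower numbers for stronger inhibition), the higher of the two numbers in hand. For the measured compounds named here, compound 1 `Cc1cc(N(C)C)nc(N[C@H]2CC[C@@H](NC(=O)c3cc(C(F)(F)F)cc(C(F)(F)F)c3)CC2)n1` gives 8 nM; the two structures differ in more than one place, so no single step is worked out between them, and the pair shows only the span of values the series has reached so far. Compound 3 `Cc1cnc(N[C@H]2CC[C@@H](CNC(=O)c3cc(Cl)cc(Cl)c3)CC2)nc1N(C)C` differs from compound 2 by 3,5-dichlorophenyl in place of 3,4-difluorophenyl on a carbonyl carbon. Going by the values given here, no measured step of this kind is available, so any expectation is loose. The expected step is a 2.7-fold lower number from compound 2 to compound 3 (0.43 log units; beyond the scatter), toward stronger inhibition, with a change no larger than the scatter also plausible. Compound 3 is estimated at 45 nM, within 12 nM to 170 nM.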

Compound 3, half-maximal inhibitory concentration: 4 nM
Beside the measured number, compound 3's estimate is 11-fold (1.05 log units) above it, outside the stated range (below it).
By their numbers in this assay, from the lowest: compounds 3 and 1 (each within the scatter of the next); then compound 2.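

At the carbonyl carbon of the amide, the aryl group strongly affects this assay: 3,5-dichlorophenyl in place of 3,4-difluorophenyl gives a 30-fold lower number from compound 2 to compound 3 (1.48 log units; beyond the scatter). For the compounds shown here, this is the first single-place step, and it shows that this position responds strongly to a change of aryl group. Nothing available accounts for the size of this step.

The step changes both halogen and ring pattern together, so their contributions cannot be separated. 3,5-Difluorophenyl and 3,4-dichlorophenyl at this carbonyl carbon would separate them.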